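Swapping a methoxy for a chloro on a shared core

The compounds below may be only part of what the source reports. "The series", "measured", "known", "first", "only" and "open" are said of these compounds alone.

Of the compounds shown here, two sharing one core have been tested in a functional assay on A549 cells (Homo sapiens) for antiproliferative activity, read by MTT assay, with a stated time of 48 h; a lower number here means a stronger inhibitor, a higher number a weaker inhibitor. Compound 1, `COc1ccc(-c2nnc(NC(=O)/C=C/c3ccccc3)s2)cc1`, gives 0.68 ug/mL in this assay, the lower of the two numbers measured. Compound 2, `Cc1ccc(-c2nnc(NC(=O)/C=C/c3ccc(C(F)(F)F)cc3)s2)cc1`, gives 1.61 ug/mL in this assay, and the gap between it and compound 1 lies beyond the usual scatter. Compound 2 differs from compound 1 in more than one place, so those two numbers alone cannot be tied to a single structural change.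

Compound 3, `O=C(/C=C/c1ccccc1)Nc1nnc(-c2ccc(Cl)cc2)s1`, has not yet been measured in this assay. It differs from compound 1 in one place: chloro in place of methoxy on an aromatic carbon. Nothing measured here shows how that exchange alone plays out, so the step from compound 1 is expected to be small, a 1.3-fold higher number from compound 1 to compound 3 (0.10 log units; within the scatter), and likely within the scatter. Compound 3 is therefore estimated at 0.85 ug/mL in this assay, with a range from 0.35 ug/mL to 2.1 ug/mL.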

Compound 3, half-maximal inhibitory concentration: 2.02 ug/mL
For compound 3 the middle estimate is 2.4-fold (0.38 log units) below the measured one; measured number inside the range.
By their numbers in this assay, from the lowest: compound 1; then compounds 2 and 3 (each within the scatter of the next).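

Exchanging methoxy for chloro on an aromatic carbon, para to a large group, gives a 3.0-fold higher number from compound 1 to compound 3 (0.47 log units; beyond the scatter) in this assay. Among these compounds, this is the first comparison here that can be tied to a single structural change, and it shows that the group at this position matters: with this core, the 4-methoxyphenyl compound is the stronger inhibitor of the pair and the 4-chlorophenyl compound the weaker. No measurement available here explains why the number rises with this exchange.

As far as these compounds go, with only these two groups compared at this position, it remains open whether a fluoro, a hydroxyl or an amine on the same carbon would give a number closer to that of methoxy or of chloro. From the compounds shown here alone, it is also open whether the same exchange would produce a similar step with a trifluoromethyl on the other aromatic ring.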